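Swapping the acid for a tetrazole in a leukotriene antagonist

The compounds below may be only part of what the source reports. "The series", "measured", "known", "first", "only" and "open" are said of these compounds alone.

Measured compounds:
Compound 1, `O=C(O)CCCCCOc1cc(-c2ccccc2)c2ccccc2n1`, 700 nM
Compound 2, `O=C(O)CCCCCOc1cc(-c2ccc(Cl)cc2)c2ccccc2n1`, 30 nM
Compound 3, `COc1cccc(-c2cc(OCCCCC(C)(C)C(=O)O)nc3ccccc23)c1`, 300 nM

In an assay on membranes from spleen (Cavia porcellus) for binding affinity to leukotriene B4 receptor 1 (Homo sapiens) (a lower number here means a stronger inhibitor, a higher number a weaker inhibitor), compound 1 gives the highest number of the three, so it is the weakest of the measured set. Compound 3 sits nearest to it, with a lower number, while compound 2 is furthest away. Going by the values given here, the only single-point step among the measured compounds is a 23-fold lower number from compound 1 to compound 2 (1.37 log units; beyond the scatter), a change on the pendant aromatic ring, not on the acid-bearing chain.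

Compound 4, `c1ccc(-c2cc(OCCCCCc3nnn[nH]3)nc3ccccc23)cc1`, keeps everything of compound 1 except the acid end: 1H-tetrazol-5-yl in place of carboxy on a saturated chain carbon, five bonds along the chain from an oxygen on an aromatic ring. Among the compounds with values here, no measured step touches this part of the molecule, so none of them bears directly on the change; compound 3 also carries a changed chain, but together with a changed aromatic ring, so its value cannot be read as a guide for the chain alone.

Without a guiding step, the estimate for compound 4 in this assay is expected to stay close to compound 1, with the step of a 1.4-fold lower number from compound 1 to compound 4 (0.15 log units; within the scatter) expected to lie within or just beyond the scatter in either direction. Compound 4 is therefore estimated at 500 nM, with a likely range from 150 nM to 2000 nM.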

Compound 4, half-maximal inhibitory concentration: 500 nM
Compound 4: the middle estimate sits on the measured number at the digits printed, and the stated range covers the measured number.
By their numbers in this assay, from the lowest: compound 2; then compounds 3, 4 and 1 (each within the scatter of the next, the first and the last beyond it).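

In this assay, 1H-tetrazol-5-yl in place of carboxy on a saturated chain carbon, five bonds along the chain from an oxygen on an aromatic ring, gives a 1.4-fold lower number from compound 1 to compound 4 (0.15 log units; within the scatter), so the two end groups cannot be told apart here. The earlier compounds shown here said little about this chain end, and this pair now shows that, on the core of compound 1, the carboxy group can be exchanged for this ring without a change beyond the scatter. Nothing available explains why the two groups read alike.

As far as these compounds go, it remains open whether the same exchange would hold on the chloro-bearing core of compound 2, where the number is already much lower. Other end groups, such as a sulfonic acid or a primary amide, and a shorter chain carrying the tetrazole also remain untested in this set.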